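Alkyl chain growth on the aryl hydrazone series

The source may report more compounds than this note shows. Statements on the series, on what has been measured and on what is new or still open speak of the compounds shown alone.

Measured so far:
compound 1 `CCc1ccc(N/N=C(\N=N\c2nnnn2-c2ccccc2)c2ccccc2)cc1` — 3800 nM
compound 2 `CC(C)c1ccc(N/N=C(\N=N\c2nnnn2-c2ccccc2)c2ccccc2)cc1` — 3400 nM

Both were run in an assay on lung for inhibition of Endothelin-converting enzyme 1 (Rattus norvegicus); a higher number here means a weaker inhibitor, a lower number a stronger inhibitor. Of the two numbers, compound 1 carries the highest; compound 2 sits within the scatter of it, the step being a 1.1-fold lower number from compound 1 to compound 2 (0.05 log units; within the scatter). Compound 3 `CC(C)(C)c1ccc(N/N=C(\N=N\c2nnnn2-c2ccccc2)c2ccccc2)cc1` is the next member and differs from compound 1 thus: tert-butyl in place of ethyl on an aromatic carbon.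

Among the compounds with values here, the only measured step that bears on this change is a 1.1-fold lower number from compound 1 to compound 2 (0.05 log units; within the scatter), where a methyl replaced a hydrogen on the saturated chain carbon attached to the ring and the number stayed within the scatter. Compound 3 carries one more methyl on that same chain carbon. Within the data shown here, nothing measured so far shows a second methyl acting differently from the first. For compound 3 in this assay a step of a 1.2-fold lower number from compound 1 to compound 3 (0.07 log units; within the scatter) is therefore expected, which is no change beyond the scatter, leaning if anything towards a slightly lower number in line with compound 2. Compound 3 is estimated at 3200 nM, with a range from 1500 nM to 7000 nM.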

Compound 3, half-maximal inhibitory concentration: 3800 nM
Compound 3: middle estimate off by 1.2-fold (0.07 log units), on the low side; low and high end bracket the measured number.
By their numbers in this assay, from the lowest: compounds 2, 1 and 3 (each within the scatter of the next).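

In this assay the second added methyl on the chain carbon bound to the ring behaves like the first (a 1.1-fold higher number from compound 2 to compound 3 (0.05 log units; within the scatter)), and the whole replacement of ethyl by tert-butyl also stays within the scatter (no change at the digits printed from compound 1 to compound 3 (within the scatter)). The series now spans 2 to 4 heavy atoms in this group, all carbon, and compounds 1, 2 and 3 cannot be told apart by their numbers, so these alkyl changes at this position give no measurable handle on inhibition. No evidence at hand speaks to what lies behind this flat result.

Going by these compounds, whether the flat response extends beyond these three alkyl groups remains open: a longer chain such as n-hexyl, plain hydrogen in place of the alkyl group, or a group carrying heteroatoms such as an amine or a carboxylic acid at the same place could each behave differently. The compounds shown also leave the rest of the core of compound 1 unchanged, so they say nothing about whether other parts of the molecule offer a larger step in this assay.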